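This account rests on a few compounds, and the source may have more. Where it says the series, first, only, none or still open, it means among the compounds named here.

Measured compounds:
- compound 1, `Cc1cc(Nc2ncc(Cl)c(Nc3cn(C)nc3S(=O)(=O)C(C)C)n2)c(OC2CC2)cc1C1COC1`, 44 nM
- compound 2, `CCNC(=O)c1cc(OC2CC2)c(Nc2ncc(Cl)c(Nc3cn(C)nc3S(=O)(=O)C(C)C)n2)cc1C`, 82 nM
- compound 3, `Cc1cc(Nc2ncc(Cl)c(Nc3cn(C)nc3S(=O)(=O)C(C)C)n2)c(OC(C)C)cc1C1CCNC1`, 364 nM

The three compounds were tested in a functional assay on NCI-H2228 cells (Homo sapiens) for inhibition, read by CellTiter-Glo, with a stated time of 96 h; a lower number here means a stronger inhibitor, a higher number a weaker inhibitor. Compound 3 has the highest number of the three; compound 2 lies a 1.9-fold higher number from compound 1 to compound 2 (0.27 log units; within the scatter), a step within the scatter, while the gap from compound 2 to compound 3 and the gap from compound 1 to compound 3 both lie beyond the scatter, so compound 3 is the weakest inhibitor of the three.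

Compound 4, `Cc1cc(Nc2ncc(Cl)c(Nc3cn(C)nc3S(=O)(=O)C(C)C)n2)c(OC(C)C)cc1C1CCN(C)C1`, is not yet measured. It differs from compound 3 in one place: methyl in place of hydrogen on an amine nitrogen in a ring.

For the measured compounds named here, none of the measured steps concerns this kind of change. Going by the values given here, the only measured step, a 1.9-fold higher number from compound 1 to compound 2 (0.27 log units; within the scatter), alters a different part of the shared core and stays within the scatter, so there is no precedent here for adding a methyl to the ring nitrogen. The expectation is therefore a small step, a 1.2-fold lower number from compound 3 to compound 4 (0.08 log units; within the scatter), not beyond the scatter. Compound 4 is estimated at 300 nM, with a range from 120 nM to 750 nM.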

Compound 4, half-maximal inhibitory concentration: 131 nM
The estimate for compound 4 lay 2.3-fold (0.36 log units) above the measured number; measured number inside the range.
By their numbers in this assay, from the lowest: compounds 1, 2 and 4 (each within the scatter of the next, the first and the last beyond it); then compound 3.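

In this assay, replacing pyrrolidin-3-yl with 1-methylpyrrolidin-3-yl gives a clear change (a 2.8-fold lower number from compound 3 to compound 4 (0.44 log units; beyond the scatter)), so adding one methyl on this ring nitrogen is enough to make the compound a stronger inhibitor. For the compounds shown here, the earlier step (a 1.9-fold higher number from compound 1 to compound 2 (0.27 log units; within the scatter)) involved a different change and stayed within the scatter, so this is the first measured sign that this position responds to a small change. No measurement here explains the gain.

The compounds shown leave open whether a longer chain on the same nitrogen, such as ethyl or propyl, or an acetyl group would strengthen inhibition further or reverse the gain. They also leave open whether the same methyl would have a similar effect in a compound that differs elsewhere on the shared core.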